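This account rests on a few compounds, and the source may have more. Where it says the series, first, only, none or still open, it means among the compounds named here.

Compounds measured so far:
compound 1 `CCC(Oc1ccc(-n2cc(C(F)(F)F)cn2)cc1)c1ccc(C(=O)NCCC(=O)O)cc1` gives 1400 nM in an assay on cells for displacement of a labelled ligand from Glucagon receptor (Homo sapiens), in the presence of a further agent that is not named here; a higher number here means a weaker inhibitor, a lower number a stronger inhibitor
compound 2 `CCCC(Oc1ccc(-n2cccn2)cc1)c1ccc(C(=O)NCCC(=O)O)cc1` gives 4100 nM in this assay
compound 3 `CCCC(Oc1ccc(-n2cc(C)cn2)cc1)c1ccc(C(=O)NCCC(=O)O)cc1` gives 1900 nM in this assay

Compound 1 stands lowest of the three numbers, yet within the scatter of compound 3 and beyond it only against compound 2. For the measured compounds named here, the one step between measured compounds that differ in a single place is a 2.2-fold lower number from compound 2 to compound 3 (0.33 log units; beyond the scatter), which concerns the pyrazole rather than the chain. Compound 4 `CC(C)CC(Oc1ccc(-n2cc(C(F)(F)F)cn2)cc1)c1ccc(C(=O)NCCC(=O)O)cc1` differs from compound 1 by isopropyl in place of methyl on a saturated chain carbon, two bonds along the chain from an aromatic carbon and an oxygen on an aromatic ring. Going by the values given here, no measured pair isolates a change in the chain, since compound 1 and compound 3 also differ at the pyrazole. Compound 4 is therefore expected to stay near compound 1, with a 1.4-fold lower number from compound 1 to compound 4 (0.15 log units; within the scatter), giving an estimate of 1000 nM within 300 nM to 3000 nM.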

Compound 4, inhibition constant: 549 nM
Compound 4: middle estimate off by 1.8-fold (0.26 log units), on the high side; measured number inside the range.
By their numbers in this assay, from the lowest: compound 4; then compounds 1 and 3 (each within the scatter of the next); then compound 2.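

In this assay, for the compounds shown here, the earlier compounds held no pair that isolated a change in the chain; here, isopropyl in place of methyl gives a 2.6-fold lower number from compound 1 to compound 4 (0.41 log units; beyond the scatter) with the rest of the molecule unchanged. This step lies beyond the scatter, so the number responds to the size of this chain in at least this one pair. Nothing shown here gives a reason for the step.

From the compounds shown here alone, how a longer chain, a cyclohexyl ring or an amine at this position would read remains open. So does whether the same change reads alike on the core of compound 2.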